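The source may report more compounds than this note shows. Statements on the series, on what has been measured and on what is new or still open speak of the compounds shown alone.

Measured compounds, with their values in an assay for inhibition of Polyunsaturated fatty acid lipoxygenase ALOX15 (Homo sapiens), with a stated time of 10 min; on this read-out higher numbers stand for weaker inhibition and lower numbers for stronger inhibition:
- compound 1, `Nc1[nH]c(C(=O)c2ccccc2)c(-c2ccc(Cl)cc2Cl)c1C(=O)c1ccc(Cl)cc1`: > 100000 nM
- compound 2, `Nc1[nH]c(C(=O)c2ccccc2)c(-c2c(F)cccc2F)c1C(=O)c1ccc(Cl)c(Cl)c1`: > 100000 nM
- compound 3, `Nc1[nH]c(C(=O)c2ccccc2)c(-c2cccc3ccccc23)c1C(=O)c1ccc(Cl)c(Cl)c1`: > 100000 nM

Each of these three values is a limit of this assay, not a number; all three sit at the limit of > 100000 nM in this assay, at which 3 of the 3 values shown sit. Compound 1 is therefore known only as a limit, and its position relative to the other two cannot be read. For the measured compounds named here, the one single-point step between measured compounds, a step that the two limits leave unreadable from compound 2 to compound 3, is likewise unreadable, as both ends are limits.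

Compound 4, `NC(=O)c1c(N)[nH]c(C(=O)c2ccccc2)c1-c1ccc(Cl)cc1Cl`, differs from compound 1 by amino in place of 4-chlorophenyl on a carbonyl carbon. Going by the values given here, no measured step touches that carbonyl carbon, so no size of effect can be taken from the measured pairs. In this assay compound 4 is expected to remain at the limit, estimated at 150000 nM with a range from 40000 nM to 600000 nM. The step from compound 1 to compound 4 is accordingly expected to be a step that the limit leaves unreadable from compound 1 to compound 4, which is not readable beyond the limit.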

Compound 4, half-maximal inhibitory concentration: > 100000 nM
Compound 4 gave a limit, no number; the forecaster's own chance of this, stated with the estimate: 85%; the middle value does not contradict the limit.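

The step between compound 1 and compound 4 cannot be read, since both values are limits, not numbers: the limit of > 100000 nM in this assay, at which 4 of the 4 values shown sit.
In this assay, as far as these compounds go, it stays open which change to the shared core, if any, gives a number rather than a limit.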